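Compound 3: a Methyl on the Aromatic Ring

The source may hold more compounds than are shown below. What is called first, only, known or untested is meant among the compounds shown, and "the series" means these compounds.

Compound 1 `CC1=C(/C=C/C(=O)/C=C/c2ccccc2)C(C)(C)CCC1O` stands at the high end of the two numbers measured: in a functional assay on PCa 2b cells (Homo sapiens) for cytotoxicity, read by MTT assay, with a stated time of 72 h (a lower number here means a stronger inhibitor, a higher number a weaker inhibitor), compound 1 gives 12600 nM, while compound 2 `CC1=C(/C=C/C(=O)/C=C/c2ccccc2C(F)(F)F)C(C)(C)CCC1O` gives 2900 nM. Among the compounds with values here, the one measured step, a 4.3-fold lower number from compound 1 to compound 2 (0.64 log units; beyond the scatter), involved a trifluoromethyl at a different place on the ring, so it bears only loosely on the present change. Compound 3 `CC1=C(/C=C/C(=O)/C=C/c2cccc(C)c2)C(C)(C)CCC1O` differs from compound 1 by methyl in place of hydrogen on an aromatic carbon. A smaller shift in the same direction, or none beyond the scatter, is expected. Compound 3 is therefore estimated at 7500 nM, in a range from 3000 nM to 18000 nM, which means an expected step of a 1.7-fold lower number from compound 1 to compound 3 (0.23 log units; within the scatter).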

Compound 3, half-maximal inhibitory concentration: 19000 nM
For compound 3 the middle estimate is 2.5-fold (0.40 log units) below the measured one; the whole stated range lies below it.
By their numbers in this assay, from the lowest: compound 2; then compounds 1 and 3 (each within the scatter of the next).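

In this assay, methyl in place of hydrogen on an aromatic carbon, meta to a large group, gives a 1.5-fold higher number from compound 1 to compound 3 (0.18 log units; within the scatter) and so does not separate the two compounds. The trifluoromethyl step stands apart from this, with a 4.3-fold lower number from compound 1 to compound 2 (0.64 log units; beyond the scatter) printed as beyond the scatter. Nothing measured here offers an explanation for this result. The compounds shown leave open whether another group at this position, such as an amine or a carboxylic acid, would give a step beyond the scatter. Going by these compounds, whether methyl elsewhere on the ring would do so also remains open.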